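The source may report more compounds than this note shows. Statements on the series, on what has been measured and on what is new or still open speak of the compounds shown alone.

In a functional assay on MCF7 cells (Homo sapiens) for antiproliferative activity, read by MTT assay, with a stated time of 48 h (a higher number here means a weaker inhibitor, a lower number a stronger inhibitor), compound 1 `N=C(N)N/N=C(/C=C/c1ccccc1Cl)c1ccccc1` gives 4200 nM and compound 2 `COc1ccc(C(/C=C/c2ccccc2)=N\NC(=N)N)cc1` gives 13000 nM, the higher of the two numbers and beyond the scatter. Compound 3 `COc1ccc(C(/C=C/c2ccccc2Cl)=N\NC(=N)N)cc1` differs from compound 2 by chloro in place of hydrogen on an aromatic carbon, phenyl to 2-chlorophenyl. Among the measured compounds shown here, no measured pair shows this change alone, but compound 1, which carries the 2-chlorophenyl group, gives 4200 nM, so a lower number is expected. The estimated 2.4-fold lower number from compound 2 to compound 3 (0.37 log units; beyond the scatter) is moderate and probably beyond the scatter. For compound 3 the expected value is 5500 nM, within an estimated range of 2000 nM to 13000 nM.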

Compound 3, half-maximal inhibitory concentration: 8100 nM
Compound 3: the middle estimate sits 1.5-fold (0.17 log units) below what was measured, within the range that was stated.
By their numbers in this assay, from the lowest: compounds 1, 3 and 2 (each within the scatter of the next, the first and the last beyond it).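

In this assay, among the compounds shown here, the first direct reading of phenyl to 2-chlorophenyl (a 1.6-fold lower number from compound 2 to compound 3 (0.21 log units; within the scatter)) shows that chloro on this aromatic carbon, ortho to a large group, does not separate from hydrogen. Methoxy in place of hydrogen reads the same way (a 1.9-fold higher number from compound 1 to compound 3 (0.29 log units; within the scatter)), so neither single change moves the number beyond the scatter. Nothing given here bears on why these steps are so small. The compounds shown leave open whether another group at this position, such as an amine or a carboxylic acid, would give a step beyond the scatter.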